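The source may hold more compounds than are shown below. What is called first, only, known or untested is meant among the compounds shown, and "the series" means these compounds.

Measured so far in a functional assay on P388 cells (Mus musculus) for inhibition (on this read-out higher numbers stand for weaker inhibition and lower numbers for stronger inhibition), for this series
- compound 1 `Cc1cccc(/C=C2\Cc3ccccc3C2=O)c1` gives 24900 nM 
- compound 2 `O=C1/C(=C/c2ccc(F)cc2)CCc2ccccc21` gives 15900 nM 

Compound 2 at 15900 nM stands within the scatter of compound 1 at 24900 nM so the two numbers do not separate. The two compounds differ in more than one place, and the pair isolates no single change.

The unmeasured compound 3 `Cc1ccc(/C=C2\CCc3ccccc3C2=O)cc1` keeps the core of compound 2 and carries one difference, methyl in place of fluoro on an aromatic carbon in short, methyl in place of fluoro on an aromatic carbon. Within the data shown here, no measured step shows this exchange, so the data give no direct size for it. Compound 1 also carries a methyl and gives 24900 nM within the scatter of compound 2, so no step beyond the scatter is expected in this assay for this exchange. The estimate puts a 1.1-fold lower number from compound 2 to compound 3 (0.03 log units; within the scatter) within the scatter, in line with that expectation. For compound 3 the estimated value is 15000 nM with an expected range of 6000 nM to 35000 nM in this series.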

Compound 3, half-maximal inhibitory concentration: 17700 nM
Compound 3: middle estimate off by 1.2-fold (0.07 log units), on the low side, and the stated range covers the measured number.
By their numbers in this assay, from the lowest: compounds 2, 3 and 1 (each within the scatter of the next).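

In this assay, methyl in place of fluoro on an aromatic carbon, para to a large group, gives a 1.1-fold higher number from compound 2 to compound 3 (0.05 log units; within the scatter). Among these compounds, this is the first direct reading of this exchange, as the earlier pair differed in more than one place and isolated no single change. At this position on the core of compound 2, the two groups do not separate on this read-out, and no information is available that could account for this result.

The compounds shown span only fluoro and methyl at this position, so it remains open whether a hydrogen, an amine, a methoxy group or a carboxylic acid on the same aromatic carbon would give a step beyond the scatter. Among the compounds shown here, it also remains open whether the exchange of fluoro for methyl reads the same way on the core of compound 1, as no pair on that core is available.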